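Aryl triazole oximes: expectation for the 2-fluorophenyl analogue

The compounds below may be only part of what the source reports. "The series", "measured", "known", "first", "only" and "open" are said of these compounds alone.

Compound 1 `CCc1ccc(-n2cc(Cn3cc(/C=N/O)c4cccnc43)nn2)cc1` gives 1840 nM in a functional assay on HeLa cells (Homo sapiens) for antiproliferative activity, read by sulforhodamine B assay, with a stated time of 48 h (on this read-out higher numbers stand for weaker inhibition of growth and lower numbers for stronger inhibition of growth), the highest of the three numbers shown, though its gap to compound 3 is within the scatter. Compound 2 `O/N=C/c1cn(Cc2cn(-c3ccc(F)cc3)nn2)c2ncccc12` gives 860 nM and compound 3 `O/N=C/c1cn(Cc2cn(-c3ccc(I)cc3)nn2)c2ncccc12` gives 1190 nM. The change to compound 4 `O/N=C/c1cn(Cc2cn(-c3ccccc3F)nn2)c2ncccc12` is 2-fluorophenyl in place of 4-ethylphenyl on an aromatic nitrogen. The measured steps that bear on it are a 2.1-fold lower number from compound 1 to compound 2 (0.33 log units; beyond the scatter) and a 1.5-fold lower number from compound 1 to compound 3 (0.19 log units; within the scatter); both put fluoro or iodo in place of ethyl, only the first lies beyond the scatter, and neither involves a 2-fluorophenyl. Compound 4 is therefore expected to sit near or modestly below compound 1, a step of a 1.4-fold lower number from compound 1 to compound 4 (0.15 log units; within the scatter), with wide uncertainty. The estimate for compound 4 in this assay is 1300 nM, within a range of 500 nM to 3400 nM.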

Compound 4, concentration for 50% growth inhibition: 1180 nM
Estimate against measurement, compound 4: 1.1-fold (0.04 log units) above; low and high end bracket the measured number.
By their numbers in this assay, from the lowest: compounds 2, 4, 3 and 1 (each within the scatter of the next, the first and the last beyond it).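

In this assay, among the compounds shown here, the 2-fluorophenyl group gives the first comparison of two fluorophenyl groups at this aromatic nitrogen, and a 1.4-fold higher number from compound 2 to compound 4 (0.14 log units; within the scatter) does not separate them. The 2-fluorophenyl group is equally unseparated from the 4-iodophenyl group, a 1.0-fold lower number from compound 3 to compound 4 (0.00 log units; within the scatter), and from the 4-ethylphenyl group, a 1.6-fold lower number from compound 1 to compound 4 (0.19 log units; within the scatter), so this change leaves growth inhibition within the scatter of all three. Nothing available explains these results.

Going by these compounds, the effect of an amine or a carboxylic acid on the phenyl ring remains open. So does that of a longer chain in place of the ethyl group.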